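The compounds below may be only part of what the source reports. "The series", "measured", "known", "first", "only" and "open" are said of these compounds alone.

Of the compounds shown here, three built on one shared core have been measured in an assay for inhibition of Amine oxidase [flavin-containing] B (Rattus norvegicus); a lower number here means a stronger inhibitor, a higher number a weaker inhibitor. Compound 3 `NC(=O)Cc1cc(=O)oc2cc(OCc3cccc(Cl)c3)ccc12` gives 30 nM, the lowest of the three numbers. Compound 2 `NNC(=O)Cc1cc(=O)oc2cc(OCc3cccc(Cl)c3)ccc12` gives 90 nM, and compound 1 `C[C@H](Nc1cc(=O)oc2cc(OCc3cccc(Cl)c3)ccc12)C(N)=O` gives 210 nM. The steps of a 3.0-fold lower number from compound 2 to compound 3 (0.48 log units; beyond the scatter) and a 7.0-fold lower number from compound 1 to compound 3 (0.85 log units; beyond the scatter) set compound 3 apart from both others, and the step of a 2.3-fold lower number from compound 1 to compound 2 (0.37 log units; beyond the scatter) separates those two from each other.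

Compound 4 `O=C(Cc1cc(=O)oc2cc(OCc3cccc(Cl)c3)ccc12)NCc1ccccc1` differs from compound 3 in a single place: benzyl in place of hydrogen on an amide-type nitrogen. For the measured compounds named here, no measured step puts a group of this kind on that nitrogen, so the comparison is indirect. The closest one is a 3.0-fold lower number from compound 2 to compound 3 (0.48 log units; beyond the scatter), where the same amide nitrogen carried an amino group rather than hydrogen and the number was higher. Replacing that hydrogen with a benzyl group is therefore expected to raise the number, with wide uncertainty. The expected step is a 5.0-fold higher number from compound 3 to compound 4 (0.70 log units; beyond the scatter). Compound 4 is estimated at 150 nM, in a likely range from 40 nM to 700 nM.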

Compound 4, half-maximal inhibitory concentration: 5000 nM
Compound 4: the middle estimate sits 33-fold (1.52 log units) below what was measured; the measured number lies above the stated range.
By their numbers in this assay, from the lowest: compound 3; then compound 2; then compound 1; then compound 4.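

In this assay, putting benzyl on the amide-type nitrogen gives a 170-fold higher number from compound 3 to compound 4 (2.22 log units; beyond the scatter), and having benzyl rather than amino on that nitrogen gives a 56-fold higher number from compound 2 to compound 4 (1.74 log units; beyond the scatter). For the compounds shown here, the only earlier step at this nitrogen, between hydrogen and amino, was modest, so these large steps show that a single change here can move the number much further than the earlier compounds revealed. Nothing measured here explains why benzyl has this effect.

Going by these compounds, it remains open whether the result depends on the aromatic ring of benzyl or on any carbon group at this nitrogen, and a methyl or ethyl group there would help separate the two. A phenyl group placed directly on the nitrogen, or a longer chain ending in phenyl, would show whether the length of the link matters.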